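From 4-methoxyphenyl to 2-methylphenyl on the shared core

This account rests on a few compounds, and the source may have more. Where it says the series, first, only, none or still open, it means among the compounds named here.

Compound 1 `Nc1ncnn2c([C@@H]3O[C@H](CO)[C@@H](O)[C@H]3O)cc(C#Cc3ccc(F)cc3)c12`: 79400 nM
Compound 2 `Nc1ncnn2c([C@@H]3O[C@H](CO)[C@@H](O)[C@H]3O)cc(-c3ccccc3)c12`: > 100000 nM (a limit)
Compound 3 `COc1ccc(-c2cc([C@@H]3O[C@H](CO)[C@@H](O)[C@H]3O)n3ncnc(N)c23)cc1`: 69300 nM

In a functional assay on NCI-H460 cells (Homo sapiens) for antiproliferative activity, with a stated time of 72 h (on this read-out higher numbers stand for weaker inhibition and lower numbers for stronger inhibition), compound 3 gives 69300 nM, which is level with compound 1 within the scatter: a 1.1-fold lower number from compound 1 to compound 3 (0.06 log units; within the scatter). For compound 2, > 100000 nM is a limit of the assay and not a number.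

Compound 4 `Cc1ccccc1-c1cc([C@@H]2O[C@H](CO)[C@@H](O)[C@H]2O)n2ncnc(N)c12` carries 2-methylphenyl in place of 4-methoxyphenyl on an aromatic carbon. The closest measured change on that carbon is an at least 1.4-fold lower number from compound 2 to compound 3 (0.15 log units; that floor lies within the scatter), and the other is an at least 1.2-fold higher number from compound 1 to compound 2 (0.10 log units; that floor lies within the scatter). Both are floors within the scatter, so no real shift is expected. The expected step is a 1.3-fold higher number from compound 3 to compound 4 (0.11 log units; within the scatter), within the scatter. For compound 4 the estimated value is 90000 nM, with an expected range of 45000 nM to 180000 nM.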

Compound 4, half-maximal inhibitory concentration: > 100000 nM
Compound 4 ended at the assay's limit (the forecaster's own chance of this, stated with the estimate: 45%); at least 1.1-fold (0.04 log units) between middle value and limit.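

The value of compound 4 is a limit of the assay and not a number. Its steps, an at least 1.4-fold higher number from compound 3 to compound 4 (0.15 log units; that floor lies within the scatter) and an at least 1.2-fold higher number from compound 1 to compound 4 (0.10 log units; that floor lies within the scatter), are floors within the scatter, so 2-methylphenyl in place of 4-methoxyphenyl on this aromatic carbon shows no shift beyond the scatter, and the step between compound 2 and compound 4 cannot be read. Compound 4 adds a second group on this carbon that ends at the limit: the limit of > 100000 nM in this assay, at which 2 of the 4 values shown sit.

Going by these compounds, how an amine or a carboxylic acid on the phenyl ring would read here stays open, as does whether any group on this carbon can move the number beyond the scatter.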